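Swapping the ring-nitrogen cap: thiocarbamate to fluorocyclobutyl amide

A few compounds are considered here, and "the series" means these few. Any claim that something is new, unique, unknown or untested is made for them only; others in the source may bear on it.

Going by the values given here, compound 2 `Cc1nc(S(C)(=O)=O)ccc1Oc1ncnc(OC2CCN(C(=S)OC3(C)CC3)CC2)c1F` carries the lower of the two numbers measured so far in a functional assay on isolated protein for inhibition of Glucose-dependent insulinotropic receptor (Rattus norvegicus), read by HTRF and cAMP accumulation (on this read-out higher numbers stand for an effect only at larger amounts of compound and lower numbers for an effect already at smaller amounts), giving 48.8 nM, while compound 1 `Cc1nc(S(C)(=O)=O)ccc1Oc1ncnc(OC2CCN(C(=O)OC(C)(C)C#N)CC2)c1F` gives 1320 nM in this assay. Among the compounds with values here, the only measured step, a 27-fold lower number from compound 1 to compound 2 (1.43 log units; beyond the scatter), sits at the same place that is changed again here. Compound 3 `Cc1nc(S(C)(=O)=O)ccc1Oc1ncnc(OC2CCN(C(=O)C3(F)CCC3)CC2)c1F` differs from compound 2 by a group of 7 heavy atoms (5 carbon, 1 oxygen, 1 fluorine; one four-membered non-aromatic ring of carbon only) in place of a group of 7 heavy atoms (5 carbon, 1 oxygen, 1 sulfur; one three-membered non-aromatic ring of carbon only), on an amine nitrogen in a ring. That step from compound 1 to compound 2 was large, but it exchanged both the alkyl part and the carbonyl-bearing part at once, so it cannot say in which direction a second exchange at this nitrogen will move the number. Within the data shown here, with only one step to lean on, a modest rise in the number is expected for compound 3, a 3.1-fold higher number from compound 2 to compound 3 (0.49 log units; beyond the scatter), and compound 3 is estimated at 150 nM in this assay, within a range from 40 nM to 600 nM.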

Compound 3, half-maximal effective concentration: 123 nM
The estimate for compound 3 lay 1.2-fold (0.09 log units) above the measured number, within the range that was stated.
By their numbers in this assay, from the lowest: compound 2; then compound 3; then compound 1.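

In this assay, a low number at this ring nitrogen does not depend on the sulfur-bearing cap of compound 2: the fluorocyclobutyl amide shows an 11-fold lower number from compound 1 to compound 3 (1.03 log units; beyond the scatter). Replacing that cap still has a measurable cost, with a 2.5-fold higher number from compound 2 to compound 3 (0.40 log units; beyond the scatter), but the sulfur, the ring size and the fluorine all change together, so this step cannot be assigned to any one of them. Nothing available explains either step.

The compounds shown leave open what each of these parts contributes on its own. A plain cyclobutyl amide, with hydrogen in place of the fluorine, and a methylcyclopropyl carbamate, with oxygen in place of the sulfur, would each separate one of these parts from the others.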